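A few compounds are considered here, and "the series" means these few. Any claim that something is new, unique, unknown or untested is made for them only; others in the source may bear on it.

In a functional assay on MCF7 cells (Homo sapiens) for cytotoxicity, read by MTT assay, with a stated time of 72 h (on this read-out higher numbers stand for weaker inhibition and lower numbers for stronger inhibition), compound 1 `COc1ccc(/C=C/C(=O)Nc2cc3c(Nc4ccc(F)c(Cl)c4)ncnc3cc2O[C@H]2CCOC2)c(OC)c1OC` gives 4650 nM and compound 2 `COc1cc(/C=C/C(=O)Nc2cc3c(Nc4ccc(F)c(Cl)c4)ncnc3cc2O[C@H]2CCOC2)cc(OC)c1O` gives 30500 nM as the higher of the two numbers, which makes it the weaker inhibitor of the pair. Compound 3 `O=C(/C=C/c1ccc(Br)cc1)Nc1cc2c(Nc3ccc(F)c(Cl)c3)ncnc2cc1O[C@H]1CCOC1` is still unmeasured and differs from compound 2 by 4-bromophenyl in place of 4-hydroxy-3,5-dimethoxyphenyl on a double-bonded chain carbon bound to a double-bonded chain carbon in one place: 4-bromophenyl in place of 4-hydroxy-3,5-dimethoxyphenyl on a double-bonded chain carbon bound to a double-bonded chain carbon. Within the data shown here, the one measured step that bears on this is a 6.6-fold higher number from compound 1 to compound 2 (0.82 log units; beyond the scatter) at that same place, modest but beyond the scatter. Among the measured compounds shown here, no measured compound carries 4-bromophenyl, so the evidence is thin. Compound 1 at 4650 nM shows that another group at this place can give a lower number, so a step of similar size toward a lower number is expected in this assay with wide uncertainty. The estimated step is a 4.4-fold lower number from compound 2 to compound 3 (0.64 log units; beyond the scatter) and it could still shrink into the scatter. For compound 3 the expected value is 7000 nM with 1800 nM to 25000 nM as the estimated range.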

Compound 3, half-maximal inhibitory concentration: 32400 nM
Compound 3: middle estimate off by 4.6-fold (0.67 log units), on the low side; measured number outside the range, above it.
By their numbers in this assay, from the lowest: compound 1; then compounds 2 and 3 (each within the scatter of the next).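

In this assay, putting 4-bromophenyl in place of 4-hydroxy-3,5-dimethoxyphenyl on a double-bonded chain carbon bound to a double-bonded chain carbon gives a 1.1-fold higher number from compound 2 to compound 3 (0.03 log units; within the scatter), so a group with no hydrogen-bond donors or acceptors and one that has both cannot be told apart at this place. Compound 1 now stands apart from both of the other groups, with a 7.0-fold higher number from compound 1 to compound 3 (0.84 log units; beyond the scatter), so the 2,3,4-trimethoxyphenyl group alone gives the lower number among these three. Nothing measured here accounts for this difference or for the absence of one between the other two groups.

From the compounds shown here alone, it remains open whether the lower number depends on all the methoxy groups of 2,3,4-trimethoxyphenyl or on only some of them. Going by these compounds, how a plain phenyl or an aminophenyl group would compare at this place also remains unknown.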